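The compounds below may be only part of what the source reports. "The series", "measured", "known", "first", "only" and "open" are said of these compounds alone.

Among the measured compounds shown here, the shared core of compound 2 `CCOC(=O)CCCCN(Cc1ccccc1)Cc1ccc2ccccc2c1` carries a benzyl group and a naphthylmethyl group on one amine nitrogen, and the three measured members differ only in the group on the remaining saturated chain carbon bound to that nitrogen. In an assay on HEK293 cells for binding affinity to Substance-K receptor (Rattus norvegicus), read by FRET, tested at 10 uM (a higher number here means more inhibition at the concentration tested (going by the name of the read-out), a lower number less inhibition), compound 2 gives 0%. It stands level with compound 1 `N#CCN(Cc1ccccc1)Cc1ccc2ccccc2c1`, which in this assay gives 0%, and with compound 3 `CCCCCCCCCCCCCCCCOC(=O)CN(Cc1ccccc1)Cc1ccc2ccccc2c1`, which in this assay gives 0%. For the measured compounds named here, the one step among the measured pairs that differ in a single place, no change at the digits printed from compound 1 to compound 2 (within the scatter), shows that exchanging the nitrile for the longer ester chain left the read-out where it was.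

Compound 4 `O=C(CN(Cc1ccccc1)Cc1ccc2ccccc2c1)OCCO` has not yet been measured in this assay. The change from compound 2 is (2-hydroxyethoxy)carbonyl in place of 3-(ethoxycarbonyl)propyl on a saturated chain carbon bound to an amine nitrogen. This step bears most directly on the step from compound 1 to compound 2, where a change of similar kind at the same place produced no movement beyond the scatter, and compound 3 with its long ester chain sits at the same level. With all three measured compounds at the same low level, no step beyond the scatter is expected, and the step from compound 2 to compound 4 is estimated as no change at the digits printed from compound 2 to compound 4 (within the scatter). Compound 4 is therefore expected to give about 0%, within a range from -8% to 10%.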

Compound 4, a percentage reported as inhibition, at one concentration (the size of the read-out at that concentration, not a potency): 0%
Compound 4: middle estimate and measured number agree at the digits printed; low and high end bracket the measured number.
By their numbers in this assay, from the lowest: compounds 1, 2, 3 and 4 (each within the scatter of the next).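

In this assay there is no change at the digits printed from compound 2 to compound 4 (within the scatter) on exchanging 3-(ethoxycarbonyl)propyl for (2-hydroxyethoxy)carbonyl, so a group with a hydrogen-bond donor on the saturated chain carbon bound to an amine nitrogen leaves the read-out level with a group that has none. The comparison with the nitrile gives the same picture, with no change at the digits printed from compound 1 to compound 4 (within the scatter), which extends the earlier finding from chain length and ester type to a terminal hydroxyl group: none of these exchanges at this position has moved the read-out beyond the scatter. Nothing available bears on why the read-out stays level across these groups.

The compounds shown leave open whether any group at this place can raise the read-out at all, for instance an amine, a carboxylic acid or an aromatic ring in place of these esters and the nitrile. They also leave open whether a change to the benzyl group or to the other substituent on the nitrogen would move it, since both stay the same throughout.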